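A Larger Amino Group on the Weaker Stereoisomer

A few compounds are considered here, and "the series" means these few. Any claim that something is new, unique, unknown or untested is made for them only; others in the source may bear on it.

Compound 1 `CNc1nc(Cl)nc(N[C@@H](C)c2ccccc2)n1` was tested in an ADME assay on the whole organism for inhibition, with Echinochloa crus-galli var. formosensis as the target, with a stated time of 4 days (on this read-out higher numbers stand for weaker inhibition and lower numbers for stronger inhibition), where compound 1 gives 26900 nM. Among the three measured compounds this is the second highest number: compound 3 `CCCNc1nc(Cl)nc(N[C@H](C)c2ccccc2)n1` gives 33100 nM, within the scatter of compound 1, whereas compound 2 `CNc1nc(Cl)nc(N[C@H](C)c2ccccc2)n1` gives 562 nM. The step of a 48-fold lower number from compound 1 to compound 2 (1.68 log units; beyond the scatter) rests on (the fact that compounds 1 and 2 differ only in the configuration as drawn). The step of a 59-fold higher number from compound 2 to compound 3 (1.77 log units; beyond the scatter) shows a large weakening when the amino side chain grows. Compound 4 `CCCN(CC)c1nc(Cl)nc(N[C@@H](C)c2ccccc2)n1` keeps the configuration of compound 1 and carries ethyl(propyl)amino in place of methylamino on an aromatic carbon. In view of the step of a 59-fold higher number from compound 2 to compound 3 (1.77 log units; beyond the scatter), a weakening is expected here as well, with a 3.0-fold higher number from compound 1 to compound 4 (0.47 log units; beyond the scatter) estimated, though compound 1 already starts from a high number. Compound 4 is therefore expected to give 80000 nM, within 20000 nM to 300000 nM.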

Compound 4, half-maximal inhibitory concentration: 282 nM
For compound 4 the middle estimate is 280-fold (2.45 log units) above the measured one, outside the stated range (below it).
By their numbers in this assay, from the lowest: compounds 4 and 2 (each within the scatter of the next); then compounds 1 and 3 (each within the scatter of the next).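

In this assay, a larger amino group at this position need not weaken inhibition: ethyl(propyl)amino in place of methylamino gives a 95-fold lower number from compound 1 to compound 4 (1.98 log units; beyond the scatter). This runs opposite to a 59-fold higher number from compound 2 to compound 3 (1.77 log units; beyond the scatter), although that step has the other drawn configuration and keeps the hydrogen-bond donor that ethyl(propyl)amino lacks. Enlarging this group therefore does not act the same way across these compounds.

Still open, as far as these compounds go, is how dimethylamino or diethylamino would behave on either stereoisomer, and how ethyl(propyl)amino would behave on the configuration of compound 2. The results give no reason for this reversal.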